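The source may report more compounds than this note shows. Statements on the series, on what has been measured and on what is new or still open speak of the compounds shown alone.

Compound 1 `COc1ccc([C@H]2CC(=O)N(c3ccccc3)C2)cc1OC1CCCC1` gives in a functional assay on HEK293 cells (Homo sapiens) for cytotoxicity (a lower number here means that less compound is tolerated, a higher number that more compound is tolerated), a limit of > 10000 nM. Compound 2 `COc1ccc([C@H]2CC(=O)N(c3ccc(C#N)cc3)C2)cc1OC1CCCC1` gives in this assay a limit of > 10000 nM. Compound 3 `COc1ccc([C@H]2CC(=O)N(c3ccccc3C)C2)cc1OC1CCCC1` gives in this assay a limit of > 10000 nM.

Compound 3 thus sits at the limit of the assay, as do the other two values; the whole set rests at the limit of > 10000 nM in this assay, at which 3 of the 3 values shown sit. Compound 4 `COc1ccc([C@H]2CC(=O)N(c3ccc([S+](C)[O-])cc3)C2)cc1OC1CCCC1` differs from compound 3 in one place: a group of 9 heavy atoms (7 carbon, 1 oxygen, 1 sulfur; one six-membered aromatic ring of carbon only) in place of a group of 7 heavy atoms (7 carbon; one six-membered aromatic ring of carbon only), on an amide-type nitrogen in a ring. The steps bearing on this change are a step that the two limits leave unreadable from compound 1 to compound 3, a step that the two limits leave unreadable from compound 2 to compound 3 and a step that the two limits leave unreadable from compound 1 to compound 2, none of which can be sized. No step beyond the scatter is therefore expected in this assay, in either direction. Compound 4 is estimated at 10000 nM, with a range of 5000 nM to 30000 nM, which means an expected step of a number no higher from compound 3 to compound 4 (the limit leaves the size open).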

Compound 4, half-maximal cytotoxic concentration: 7510 nM
Compound 4: the middle estimate sits 1.3-fold (0.12 log units) above what was measured, within the range that was stated.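

Going by these compounds alone, with the group holding sulfur and oxygen on an aromatic carbon, compound 4 is the first of the set to give a number rather than a limit in this assay, which yields the first readable steps: an at least 1.3-fold lower number from compound 3 to compound 4 (0.12 log units; that floor lies within the scatter), an at least 1.3-fold lower number from compound 2 to compound 4 (0.12 log units; that floor lies within the scatter) and an at least 1.3-fold lower number from compound 1 to compound 4 (0.12 log units; that floor lies within the scatter). These are floors only, and the steps among compound 1, compound 2 and compound 3 cannot be read. The other values remain limits: the limit of > 10000 nM in this assay, at which 3 of the 4 values shown sit.

Going by these compounds, the true size of these steps stays open. So does whether an amine or a carboxylic acid on that aromatic carbon would also give a number in this assay.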